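Chalcone-pyrazole series: methoxy loss and a difluorophenyl step

The source may report more compounds than this note shows. Statements on the series, on what has been measured and on what is new or still open speak of the compounds shown alone.

Measured compounds:
compound 1 `COc1ccc(C(=O)/C=C/c2cc(-c3cc(OC)c(OC)c(OC)c3)n[nH]2)cc1OC` — -73%
compound 2 `COc1ccc(C(=O)/C=C/c2cc(-c3cc(OC)c(OC)c(OC)c3)n[nH]2)cc1` — -29%

In a functional assay on IGROV-1 cells (Homo sapiens) for cytotoxicity, read by sulforhodamine B assay, with a stated time of 48 h, tested at 100 uM (on this read-out higher numbers stand for a weaker effect at the one concentration tested and lower numbers for a stronger effect), compound 1 gives -73% and compound 2 gives -29%. Among the measured compounds shown here, compound 2 holds the highest of the two numbers; its one neighbour is compound 1, and the step of a number 44 percentage points higher from compound 1 to compound 2 (beyond the scatter) is the only one in hand. Compound 3 `COc1cc(-c2cc(/C=C/C(=O)c3ccc(F)c(F)c3)[nH]n2)cc(OC)c1OC` is not yet measured. It differs from compound 2 by 3,4-difluorophenyl in place of 4-methoxyphenyl on a carbonyl carbon on a carbonyl carbon whose other neighbours are a double-bonded chain carbon. For the measured compounds named here, no measured pair covers this change; the step from compound 1 to compound 2 bears on it only loosely, in that it also removed a methoxy from that aryl ring and the number rose well beyond the scatter. Compound 3 is therefore expected to move by a number 17 percentage points higher from compound 2 to compound 3 (beyond the scatter), weakly upward if at all. The estimate for compound 3 in this assay is -12%, within -60% to 30%.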

Compound 3, a percentage reported as activity, at one concentration (the size of the read-out at that concentration, not a potency): -1%
Compound 3: middle estimate off by 11 percentage points, on the low side; the measured number falls inside the stated range.
By their numbers in this assay, from the lowest: compound 1; then compound 2; then compound 3.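

In this assay, the aryl group on the carbonyl carbon responds to a full exchange as well as to the loss of one methoxy: 3,4-difluorophenyl in place of 4-methoxyphenyl gives a number 28 percentage points higher from compound 2 to compound 3 (beyond the scatter) and thus a weaker effect at the one concentration tested. Set against 3,4-dimethoxyphenyl, the same group gives a number 72 percentage points higher from compound 1 to compound 3 (beyond the scatter) as the largest step in hand, so with the core held constant the effect fades in the order 3,4-dimethoxyphenyl, 4-methoxyphenyl, 3,4-difluorophenyl. Nothing available accounts for this order.

These compounds leave open whether the rise follows from the loss of methoxy or from the arrival of fluorine. A plain phenyl or a 4-aminophenyl on the same carbonyl carbon would help to separate the two.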